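Amide series: fluoro in place of methyl

The source may report more compounds than this note shows. Statements on the series, on what has been measured and on what is new or still open speak of the compounds shown alone.

Measured so far:
compound 1 `O=C(Nc1cccc(-c2nc3ccccc3s2)c1)c1ccc(Cl)nc1Cl`: > 25000 nM
compound 2 `Cc1ccc(-c2nc3ccccc3s2)cc1NC(=O)c1cnccc1Cl`: > 25000 nM

In an ADME assay on BJ cells (Homo sapiens) for inhibition, with a stated time of 72 h (a lower number here means that less compound is needed, a higher number that more compound is needed for the effect), compound 1 gives > 25000 nM, which is a limit of the assay and not a number. Compound 2 gives > 25000 nM in this assay, again a limit. Compound 2 therefore stands where both values sit, at the limit described by the limit of > 25000 nM in this assay, at which 2 of the 2 values shown sit.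

Compound 3 `O=C(Nc1cc(-c2nc3ccccc3s2)ccc1F)c1cnccc1Cl` differs from compound 2 by fluoro in place of methyl on an aromatic carbon. Within the data shown here, no measured step covers this change; with compound 2 at the limit, the expected step that the limit leaves unreadable from compound 2 to compound 3 is none beyond the scatter. Compound 3 is expected to give 30000 nM, range 8000 nM to 120000 nM, most likely reported as a limit.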

Compound 3, half-maximal effective concentration: > 25000 nM
Compound 3: a limit, no number; the forecaster's own chance of this, stated with the estimate: 80%; the middle value is on the limit's open side.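

In this assay, among these compounds, compound 2 and compound 3 both stand as limits of the assay, and no step between them can be read. The compounds shown leave open what size of effect, if any, fluoro in place of methyl has on an aromatic carbon in this assay.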